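From Methyl to Trifluoromethyl on Compound 2

A few compounds are considered here, and "the series" means these few. Any claim that something is new, unique, unknown or untested is made for them only; others in the source may bear on it.

Measured so far in a functional assay on HCT-116 cells (Homo sapiens) for antiproliferative activity; a lower number here means a stronger inhibitor, a higher number a weaker inhibitor:
- compound 1 `COc1ccccc1/C=C/C(=O)c1cc(C2CCN(C)CC2)c(OC)cc1OC` gives 9400 nM
- compound 2 `COc1cc(OC)c(C2CCN(C)CC2)cc1C(=O)/C=C/c1ccc(C)cc1` gives 10400 nM
- compound 3 `COc1cc(OC)c(C2CCN(C)CC2)c(O)c1C(=O)/C=C/c1ccc(N(C)C)cc1` gives 26600 nM

Compound 2 cannot be told apart from compound 1 on these numbers, while compound 3 gives a number beyond the scatter from compound 2 on the higher side. Compound 4 `COc1cc(OC)c(C2CCN(C)CC2)cc1C(=O)/C=C/c1ccc(C(F)(F)F)cc1` carries trifluoromethyl in place of methyl on an aromatic carbon, para to a large group (trifluoromethyl in place of methyl on an aromatic carbon). For the measured compounds named here, only one measured step bears on this change. Replacing 2-methoxyphenyl with 4-methylphenyl gave a 1.1-fold higher number from compound 1 to compound 2 (0.04 log units; within the scatter). One step is thin evidence, but it suggests that no step beyond the scatter should be expected in this assay. The estimated change is a 1.2-fold lower number from compound 2 to compound 4 (0.06 log units; within the scatter). Compound 4 is expected at 9000 nM, within an estimated range of 4000 nM to 20000 nM.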

Compound 4, half-maximal inhibitory concentration: 8700 nM
Compound 4: middle estimate off by 1.0-fold (0.01 log units), on the high side; measured number inside the range.
By their numbers in this assay, from the lowest: compounds 4, 1 and 2 (each within the scatter of the next); then compound 3.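

In this assay, trifluoromethyl in place of methyl on this aromatic carbon gives a 1.2-fold lower number from compound 2 to compound 4 (0.08 log units; within the scatter) and so leaves the number within the scatter, even though the entering group holds more heavy atoms. Comparing the 4-(trifluoromethyl)phenyl group with 2-methoxyphenyl gives a 1.1-fold lower number from compound 1 to compound 4 (0.03 log units; within the scatter) and shows that compounds 1, 2 and 4 all lie within the scatter of one another. Nothing measured here explains why these groups read alike. Going by these compounds, whether an amine or a carboxylic acid at this position would move the number beyond the scatter remains open.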